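Ethoxy to methyl on the amide-side ring: expected effect

This account rests on a few compounds, and the source may have more. Where it says the series, first, only, none or still open, it means among the compounds named here.

Compound 1 `C=CC1=C(C(=O)Nc2ccc(OCC)cc2)C(c2ccc(OC)cc2)OC1` is tested in a functional assay on HeLa cells (Homo sapiens) for cytotoxicity, read by MTT assay, with a stated time of 24 h (a lower number here means a stronger inhibitor, a higher number a weaker inhibitor), where compound 1 gives only the limit > 100000 nM and not a number. Compound 2 `C=CC1=C(C(=O)NC(C)(C)C)C(c2ccc(Cl)c(Cl)c2)OC1` likewise gives only the limit > 100000 nM in this assay. For the measured compounds named here, both values sit at the limit of > 100000 nM in this assay, at which 2 of the 2 values shown sit, so no measured step resolves a size or a direction. Compound 3 `C=CC1=C(C(=O)Nc2ccc(C)cc2)C(c2ccc(OC)cc2)OC1` differs from compound 1 by methyl in place of ethoxy on an aromatic carbon. With both measured compounds at the limit, the step that the limit leaves unreadable from compound 1 to compound 3 is expected to stay at or near the limit rather than move beyond the scatter. Compound 3 is therefore estimated at 150000 nM, within 50000 nM to 500000 nM, most likely reported again as a limit.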

Compound 3, half-maximal inhibitory concentration: > 100000 nM
Compound 3: a limit, no number (the forecaster's own chance of this, stated with the estimate: 80%); the middle value does not contradict the limit.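

For the compounds shown here, no step from compound 1 to compound 3 can be read, as both results are limits: the limit of > 100000 nM in this assay, at which 3 of the 3 values shown sit.

The compounds shown leave open which change to the shared core, if any, gives a number rather than a limit in this assay on this series.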